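Removing one sulfonamide substituent from compound 2

This account rests on a few compounds, and the source may have more. Where it says the series, first, only, none or still open, it means among the compounds named here.

Three compounds measured so far in a physicochemical assay for lipophilicity, at pH 7.4; on this read-out lower numbers stand for lower lipophilicity and higher numbers for higher lipophilicity:
Compound 1 `O=C1CC(C2CCOCC2)Oc2ccc(S(=O)(=O)N3CCCC3c3ccccc3C(F)(F)F)cc21` gives 3.5
Compound 2 `CCc1ccc(N(CC2CC2)S(=O)(=O)c2ccc3c(c2)C(=O)CC(C2CCOCC2)O3)cc1` gives 3.77
Compound 3 `Cc1ccc(N(CC(C)C)S(=O)(=O)c2ccc3c(c2)C(=O)CC(C2CCOCC2)O3)c(C)c1` gives 4.28

Repeated measurements of this kind never agree exactly, so small gaps carry no meaning. Compound 2 at 3.77 cannot be told apart from compound 1 at 3.5. The gap between them lies within the usual scatter. Compound 3 at 4.28 reads higher than compound 2, and that gap lies beyond the scatter.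

Compound 4 `CCc1ccc(NS(=O)(=O)c2ccc3c(c2)C(=O)CC(C2CCOCC2)O3)cc1` is compound 2 altered in a single place: hydrogen in place of cyclopropylmethyl on a sulfonamide nitrogen. Among the compounds with values here, no two measured compounds differ in only one place, so the data offer no direct measure of this change, and the expectation rests on the structural change alone. A group made only of carbon is leaving, and on this assay such a loss usually goes with a lower number. A fall beyond the scatter is therefore expected, starting from compound 2 at 3.77 on this scale. Within the data shown here, the estimated change is a number 0.67 log units lower from compound 2 to compound 4 (beyond the scatter) in size, and no measured pair can yet check it. For compound 4 the expected value is 3.1 within an estimated range of 2.7 to 3.5 on the same scale.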

Compound 4, distribution coefficient: 2.67
Compound 4: middle estimate off by 0.43 log units, on the high side; measured number below the stated range.
By their numbers in this assay, from the lowest: compound 4; then compounds 1 and 2 (each within the scatter of the next); then compound 3.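

Within the data shown here, this is the first step that can be read directly, as the two compounds involved differ in one place only. In this assay, hydrogen in place of cyclopropylmethyl on a sulfonamide nitrogen gives a number 1.10 log units lower from compound 2 to compound 4 (beyond the scatter), which counts as a large step. The earlier compounds differed in several places at once, so they could not show that a change at this nitrogen alone, with the rest of the molecule left untouched, is enough to move the number this far, and nothing measured here accounts for the size of the step.

A single step cannot show whether the same swap would move the number as far in a compound with a different aromatic group on this nitrogen, such as compound 3 with its own substituents. It also leaves open how the number would respond to other groups at this position, such as a plain methyl, a longer carbon chain, or a chain ending in an amine or a carboxylic acid.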